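This account rests on a few compounds, and the source may have more. Where it says the series, first, only, none or still open, it means among the compounds named here.

Measured so far in an assay on isolated protein for activation of Nicotinamide phosphoribosyltransferase (Homo sapiens); on this read-out lower numbers stand for an effect already at smaller amounts and higher numbers for an effect only at larger amounts of compound:
compound 1 `O=C(NCc1ccncc1)Nc1ccc(S(=O)(=O)c2cccc(Cl)c2)cc1` — 69 nM
compound 2 `CN(C1CCCC1)S(=O)(=O)c1ccc(NC(=O)NCc2ccncc2)cc1` — 123 nM
compound 3 `O=C(NCc1cnco1)Nc1ccc(S(=O)(=O)c2ccccc2)cc1` — 77 nM

Compound 3 stands among these with a number that differs from those of compound 1 and compound 2 only within the usual scatter; the one single-point step known, a 1.8-fold higher number from compound 1 to compound 2 (0.25 log units; within the scatter), concerns the sulfonyl side and stays within the scatter too. Compound 4 `O=C(NCc1ccncc1)Nc1ccc(S(=O)(=O)c2ccccc2)cc1` arises from compound 3 by one change: pyridin-4-yl in place of 1,3-oxazol-5-yl on a saturated chain carbon bound to an amide-type nitrogen. Going by the values given here, no measured pair tests this exchange, and compound 1, which carries the same pyridin-4-yl group but on a different sulfonyl partner, gives a number close to that of compound 3. Compound 4 is therefore expected to show a 1.0-fold lower number from compound 3 to compound 4 (0.01 log units; within the scatter), with an estimate of 75 nM in this assay, in the range 35 nM to 160 nM.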

Compound 4, half-maximal effective concentration: 85 nM
Beside the measured number, compound 4's estimate is 1.1-fold (0.05 log units) below it; the range from low to high includes it.
By their numbers in this assay, from the lowest: compounds 1, 3, 4 and 2 (each within the scatter of the next).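

In this assay, the direct exchange of 1,3-oxazol-5-yl for pyridin-4-yl on a saturated chain carbon bound to an amide-type nitrogen gives a 1.1-fold higher number from compound 3 to compound 4 (0.04 log units; within the scatter), so these two groups cannot be told apart here. On the sulfonyl side, hydrogen in place of chloro gives a 1.2-fold higher number from compound 1 to compound 4 (0.09 log units; within the scatter), and phenyl in place of cyclopentyl(methyl)amino gives a 1.4-fold lower number from compound 2 to compound 4 (0.16 log units; within the scatter), so neither change can be told from scatter either. No supporting data bear on these results.

Only these two ring groups are shown on that chain carbon, so what an amine or a carboxylic acid there would do remains open.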